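This account rests on a few compounds, and the source may have more. Where it says the series, first, only, none or still open, it means among the compounds named here.

Compound 1 `O=c1ccoc2cc(OCc3cn(Cc4cccc(Br)c4)nn3)ccc12` gives > 300000 nM in an ADME assay on L02 cells (Homo sapiens) for cytotoxicity, read by MTT assay, with a stated time of 48 h (a higher number here means a weaker inhibitor, a lower number a stronger inhibitor), which is a limit of this assay and not a number.
Compound 2 `O=c1ccoc2cc(OCc3cn(Cc4ccc(Br)cc4)nn3)ccc12` gives > 300000 nM, again a limit.
Compound 3 `N#Cc1ccc(Cn2cc(COc3ccc4c(=O)ccoc4c3)nn2)cc1` gives > 300000 nM, also a limit.

Compound 1 therefore stands at the limit shared by all three measured compounds (the limit of > 300000 nM in this assay, at which 3 of the 3 values shown sit). Compound 4 `N#Cc1cccc(Cn2cc(COc3ccc4c(=O)ccoc4c3)nn2)c1` differs from compound 1 by cyano in place of bromo on an aromatic carbon. The measured steps that touch this kind of change, a step that the two limits leave unreadable from compound 2 to compound 3 and a step that the two limits leave unreadable from compound 1 to compound 3, cannot be read in size, and the same holds for a step that the two limits leave unreadable from compound 1 to compound 2. Nothing in the data points to a change beyond the scatter, so compound 4 is expected to sit at the limit as well, a step that the limit leaves unreadable from compound 1 to compound 4. The estimate for compound 4 is 400000 nM, expected between 150000 nM and 1000000 nM.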

Compound 4, half-maximal inhibitory concentration: > 300000 nM
Compound 4: a limit, no number; the forecaster's own chance of this, stated with the estimate: 85%; the middle value does not contradict the limit.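

Within the data shown here, compound 4 gives > 300000 nM, a limit and not a number, so no step between it and compound 1, compound 2 or compound 3 can be read. The compounds shown leave open whether swapping bromo for cyano, or moving either group, changes the reading in this assay at all: the limit of > 300000 nM in this assay, at which 4 of the 4 values shown sit.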